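A few compounds are considered here, and "the series" means these few. Any claim that something is new, unique, unknown or untested is made for them only; others in the source may bear on it.

Compound 1 `COc1cc(CC2C(C#N)=C(N)N(c3ccc(S(N)(=O)=O)cc3)C3=C2C(=O)CCC3)ccc1O`: in a functional assay on Ehrlich cells (Mus musculus) for antiproliferative activity, read by trypan blue exclusion, with a stated time of 2 h, tested at 50 ug/mL (a higher number here means a stronger effect of the compound at the concentration tested, a lower number a weaker effect), compound 1 gives 90%.
Compound 2 `N#CC1=C(N)N(c2ccc(S(N)(=O)=O)cc2)C2=C(C(=O)CCC2)C1c1cccc([N+](=O)[O-])c1`: in this assay compound 2 gives 73%.
Compound 3 `COc1ccc2ccccc2c1C1C(C#N)=C(N)N(c2ccc(S(N)(=O)=O)cc2)C2=C1C(=O)CCC2`: in this assay compound 3 gives 70%.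

Compound 3 holds the lowest of the three numbers, but its gap to compound 2, a number 3 percentage points lower from compound 2 to compound 3 (within the scatter), lies within the scatter, while compound 1 stands clearly higher, a number 20 percentage points lower from compound 1 to compound 3 (beyond the scatter). Compound 4 `COc1ccc(C2C(C#N)=C(N)N(c3ccc(S(N)(=O)=O)cc3)C3=C2C(=O)CCC3)c2ccccc12` differs from compound 3 by 4-methoxynaphthalen-1-yl in place of 2-methoxynaphthalen-1-yl on a saturated ring carbon. Going by the values given here, no measured step exchanges one methoxynaphthalenyl group for the other. The exchanges of one aryl group for another gave a number 17 percentage points lower from compound 1 to compound 2 (beyond the scatter) and a number 20 percentage points lower from compound 1 to compound 3 (beyond the scatter), both modest, and a number 3 percentage points lower from compound 2 to compound 3 (within the scatter). Because a number 3 percentage points lower from compound 2 to compound 3 (within the scatter) lies within the scatter for the most similar exchange, compound 4 is expected to show no change at the digits printed from compound 3 to compound 4 (within the scatter), no step beyond the scatter. Compound 4 is therefore estimated at 70%, with a range from 55% to 85%.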

Compound 4, a percentage reported as activity, at one concentration (the size of the read-out at that concentration, not a potency): 30%
Compound 4: the middle estimate sits 40 percentage points above what was measured; measured number outside the range, below it.
By their numbers in this assay, from the lowest: compound 4; then compounds 3 and 2 (each within the scatter of the next); then compound 1.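

Exchanging 2-methoxynaphthalen-1-yl for 4-methoxynaphthalen-1-yl on the saturated ring carbon, two groups with the same atoms joined differently, gives a number 40 percentage points lower from compound 3 to compound 4 (beyond the scatter) in this assay and so shows that this position can respond strongly to where the methoxy group sits on the naphthalene. The same group also gives a number 43 percentage points lower from compound 2 to compound 4 (beyond the scatter) and a number 60 percentage points lower from compound 1 to compound 4 (beyond the scatter) and leaves compound 4 lowest of the four. Nothing given here accounts for this drop. As far as these compounds go, it remains open whether a dimethylamino group or a carboxylic acid in place of that methoxy group would restore the read-out or lower it further.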